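A few compounds are considered here, and "the series" means these few. Any claim that something is new, unique, unknown or untested is made for them only; others in the source may bear on it.

Measured so far in a functional assay on cells (Cancer cell lines, Homo sapiens) for cytotoxicity, read by sulforhodamine B assay, with a stated time of 48 h; a higher number here means a weaker inhibitor of growth, a lower number a stronger inhibitor of growth:
- compound 1 `COc1ccc(C2=NN(C3=NC(=O)/C(=C4\C(=O)Nc5ccccc54)S3)C(c3ccc(OC)cc3)C2)cc1`: 100000 nM
- compound 2 `COc1ccc(C2=NN(C3=NC(=O)/C(=C4\C(=O)Nc5ccc(Br)cc54)S3)C(c3ccc(OC)cc3)C2)cc1`: 270 nM

Compound 2 stands lowest of the two numbers; its nearest neighbour is compound 1, separated by a 370-fold lower number from compound 1 to compound 2 (2.57 log units; beyond the scatter), a bromo in place of hydrogen on an aromatic carbon. Compound 3 `COc1ccc(C2CC(c3ccc4ccccc4c3)=NN2C2=NC(=O)/C(=C3\C(=O)Nc4ccc(Br)cc43)S2)cc1` differs from compound 2 by naphthalen-2-yl in place of 4-methoxyphenyl on a carbon with a double bond to nitrogen. For the measured compounds named here, the single measured step changes a different part of the shared core and does not bear on this replacement; no measured step informs the exchange of one aryl group for another here. The expectation for this assay is therefore no change beyond the scatter, with a wide range given the absence of guidance. Compound 3 is expected near 300 nM (range 80 nM to 1500 nM). The expected step is a 1.1-fold higher number from compound 2 to compound 3 (0.05 log units; within the scatter).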

Compound 3, concentration for 50% growth inhibition: 59 nM
For compound 3 the middle estimate is 5.1-fold (0.71 log units) above the measured one; the whole stated range lies above it.
By their numbers in this assay, from the lowest: compound 3; then compound 2; then compound 1.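

The carbon with a double bond to nitrogen is a second place where this assay responds: naphthalen-2-yl in place of 4-methoxyphenyl gives a 4.6-fold lower number from compound 2 to compound 3 (0.66 log units; beyond the scatter) on top of the bromo compound. The entering group has a second six-membered aromatic ring and no oxygen, and these two differences are not separated here. No measurement given here explains the step.

Open, from the compounds shown here alone, is whether a plain phenyl, or a phenyl carrying an amine or a carboxylic acid, would hold this number at this position. Also open, going by these compounds, is any replacement of the 4-methoxyphenyl group on the other ring atom that bears one.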